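The source may hold more compounds than are shown below. What is called first, only, known or untested is meant among the compounds shown, and "the series" means these compounds.

Working notes on the series. All four compounds share one core and differ only in the group on the ring nitrogen and in the substitution of the aryl ring. Compound 1 `COc1cc(C2CC(c3cc4ccccc4nc3C)=NN2C(C)=O)cc(OC)c1OC` carries an acetyl on that nitrogen. In an ADME assay on A549 cells (Homo sapiens) for cytotoxicity, read by MTT assay, with a stated time of 48 h (on this read-out higher numbers stand for weaker inhibition and lower numbers for stronger inhibition), compound 1 gives > 200 ug/mL, which is a limit of the assay and not a number. Going by the values given here, compound 1 therefore stands at the limit of > 200 ug/mL in this assay, at which 1 of the 3 values shown sits, so no step to or from it can be sized from the data. Compound 2 `COc1ccc(C2CC(c3cc4ccccc4nc3C)=NN2c2ccccc2)c(OC)c1OC` gives 143 ug/mL in this assay. Compound 3 `CCOc1c(F)c(F)c(C2CC(c3cc4ccccc4nc3C)=NN2C(C)=O)c(F)c1F` gives 115 ug/mL in this assay, and the two numbers for compound 2 and compound 3 lie within the usual scatter of each other. Compound 4 `COc1cc(C2CC(c3cc4ccccc4nc3C)=NN2c2ccccc2)cc(OC)c1OC` is not yet measured and differs from compound 1 by phenyl in place of acetyl on an amine nitrogen in a ring. Among the compounds with values here, no pair of measured compounds differs in one place, so the size of this change is not fixed by the data; the only phenyl-bearing compound measured, compound 2, gave a number rather than a limit. The step from compound 1 to compound 4 is expected to be modest and toward stronger inhibition, an at least 1.3-fold lower number from compound 1 to compound 4 (0.12 log units; that floor lies within the scatter), with a real chance that only a limit is reported again. Compound 4 is estimated at 150 ug/mL, within 70 ug/mL to 250 ug/mL.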

Compound 4, half-maximal inhibitory concentration: > 200 ug/mL
Compound 4 was reported as a limit; the forecaster's own chance of this, stated with the estimate: 35%; middle value at least 1.3-fold (0.12 log units) away from the limit.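

In this assay compound 4 gives > 200 ug/mL, a limit of the assay and not a number. Compound 1 also stands at a limit, so no step between compound 1 and compound 4 can be read: the limit of > 200 ug/mL in this assay, at which 2 of the 4 values shown sit.

The compounds shown leave open whether phenyl in place of acetyl on an amine nitrogen in a ring changes inhibition at all.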